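Chloromethyl replacing anilino on a shared coumarin-type core

The source may report more compounds than this note shows. Statements on the series, on what has been measured and on what is new or still open speak of the compounds shown alone.

Measured so far in an assay on isolated protein (strain Sprague-Dawley) for inhibition of Amine oxidase [flavin-containing] A (Rattus norvegicus), read by spectrophotometry, with a stated time of 5 min, tested at 10 uM; on this read-out lower numbers stand for less inhibition and higher numbers for more inhibition at the one concentration tested (going by the name of the read-out):
- compound 1, `CCOc1cc(=O)oc2cc(OCc3cccc(Cl)c3)ccc12`: compound 1 gives 2%
- compound 2, `O=c1cc(Nc2ccccc2)c2ccc(OCc3cccc(Cl)c3)cc2o1`: compound 2 gives 0%

Among the compounds with values here, compound 2 stands lowest of the two numbers, though its nearest neighbour, compound 1, lies within the scatter of it: the single step of a number 2 percentage points lower from compound 1 to compound 2 (within the scatter) is within the scatter. The unmeasured compound 3, `O=c1cc(CCl)c2ccc(OCc3cccc(Cl)c3)cc2o1`, differs from compound 2 in one place, (chloromethyl in place of anilino on an aromatic carbon). Within the data shown here, no measured step involves a chloromethyl group, so the only step that bears on the question is the one from compound 1 to compound 2, and it was flat. Both measured compounds sit near the floor of the read-out, which leaves room only upward. Compound 3 is therefore expected to show a step of a number 10 percentage points higher from compound 2 to compound 3 (within the scatter), a small rise at most, and its estimate is 10% with a range from 0% to 40%.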

Compound 3, a percentage reported as inhibition, at one concentration (the size of the read-out at that concentration, not a potency): 21%
Compound 3: middle estimate off by 11 percentage points, on the low side; the range from low to high includes it.
By their numbers in this assay, from the lowest: compounds 2 and 1 (each within the scatter of the next); then compound 3.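

In this assay the position opposite the ring oxygen proved able to respond, with a number 21 percentage points higher from compound 2 to compound 3 (beyond the scatter) and a number 19 percentage points higher from compound 1 to compound 3 (beyond the scatter) while the earlier change from ethoxy to anilino had stayed within the scatter. Chloromethyl is thus the first group in this short series to lift the number clear of the floor of the read-out, although the rise is modest and describes the effect at one concentration, not a potency. Nothing measured here accounts for the rise.

The compounds shown leave open whether the chlorine itself matters or whether a plain methyl or a hydroxymethyl in the same place would give a similar number. They also leave open how a longer chain ending in chlorine, or a bromomethyl group, would behave at this position.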